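The compounds below may be only part of what the source reports. "The series", "measured", "known", "first", "only" and "open" are said of these compounds alone.

In a functional assay on MCF7 cells (Homo sapiens) for cytotoxicity, read by MTT assay, with a stated time of 6 days (on this read-out lower numbers stand for an effect already at smaller amounts and higher numbers for an effect only at larger amounts of compound), so far, each entry is a limit of the assay:
- compound 1 `O=C(O)c1c(-c2ccc([N+](=O)[O-])cc2)oc2ccccc2c1=O` gives > 25 ug/mL (limit)
- compound 2 `O=c1cc(-c2ccc([N+](=O)[O-])cc2)oc2cc(O)ccc12` gives > 25 ug/mL (limit)
- compound 3 `Nc1ccc(-c2cc(=O)c3ccc(O)cc3o2)cc1` gives > 25 ug/mL (limit)

Compound 3 therefore stands at a limit and has no number. The change to compound 4 `CC(C)(C)[Si](C)(C)Oc1ccc(-c2cc(=O)c3ccc(O)cc3o2)cc1` is a group of 8 heavy atoms (6 carbon, 1 oxygen, 1 silicon; no ring) in place of one nitrogen atom, on an aromatic carbon, with the amino group leaving an aromatic carbon para to a large group. Among the compounds with values here, the one measured step bearing on this is a step that the two limits leave unreadable from compound 2 to compound 3, which concerns the same aromatic carbon but has no readable size. Within the data shown here, no step size can be carried over because the limit of > 25 ug/mL in this assay, at which 3 of the 3 values shown sit, and the entering group has no measured counterpart. No step beyond the scatter is therefore expected in this assay, in either direction, although the data do not exclude one. The expected size is a number no higher from compound 3 to compound 4 (the limit leaves the size open) and the result may well be another limit. For compound 4 the estimated value is 25 ug/mL with an expected range from 10 ug/mL to 50 ug/mL as the close of these notes.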

Compound 4, concentration for half-maximal effect: 4.66 ug/mL
Compound 4: middle estimate off by 5.4-fold (0.73 log units), on the high side; the whole stated range lies above it.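

In this assay, replacing amino on the aromatic carbon para to a large group with the group of 8 heavy atoms (6 carbon, 1 oxygen, 1 silicon) gives an at least 5.3-fold lower number from compound 3 to compound 4 (0.72 log units; beyond the scatter), and replacing nitro there with the same group gives an at least 5.3-fold lower number from compound 2 to compound 4 (0.72 log units; beyond the scatter). This position is therefore not indifferent to what it carries, which compound 2 and compound 3 could not show, since the step between those two cannot be read. Both new steps are open in size on one side: the limit of > 25 ug/mL in this assay, at which 3 of the 4 values shown sit.

On these data alone, whether the silicon atom, the oxygen link or the sheer size of the entering group goes with the lower number stays open. A hydroxyl or a methoxy group on the same aromatic carbon would help separate these, and the shown compounds do not say how either would read.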